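A few compounds are considered here, and "the series" means these few. Any claim that something is new, unique, unknown or untested is made for them only; others in the source may bear on it.

Values in an ADME assay on microsomes from liver (Homo sapiens) for metabolic stability, read by LC-MS, using NADPH, with a stated time of 10 min, tested at 0.1 uM (a lower number here means slower removal, a higher number faster removal of the compound), stand as follows
Compound 1 `CC1SC(c2cccc(C(=O)NCCCCc3ccccc3)c2)N(c2ccc(C3CC3)cc2)C1=O` gives 2010 mL.min-1.g-1
Compound 2 `O=C(NCCCCn1cccn1)c1cccc(C2SCC(=O)N2c2ccccn2)c1` gives 82.1 mL.min-1.g-1
Compound 3 `O=C(NCCCCc1ccccc1)c1cccc(C2SCC(=O)N2c2ccccn2)c1` gives 412 mL.min-1.g-1

Compound 3 with 412 mL.min-1.g-1 holds the second highest of the three numbers. The change to compound 4 `CC(F)(F)c1cccc(N2C(=O)CSC2c2cccc(C(=O)NCCCCc3ccccc3)c2)c1` is a group of 10 heavy atoms (8 carbon, 2 fluorine; one six-membered aromatic ring of carbon only) in place of a group of 6 heavy atoms (5 carbon, 1 nitrogen; one six-membered aromatic ring with 1 hetero atom), on an amide-type nitrogen in a ring and pyridin-2-yl is the group that leaves. For the measured compounds named here, the only measured step is a 5.0-fold higher number from compound 2 to compound 3 (0.70 log units; beyond the scatter) and it is modest, but it sits on a saturated chain carbon and bears only indirectly on the ring nitrogen. Differing from compound 3 in more than one place, compound 1 also carries an aromatic ring of carbon only on that nitrogen, and with compound 1 at 2010 mL.min-1.g-1 a rise in this assay beyond the scatter is expected. This rests on one imperfect comparison, so the expectation stays loose. The estimated step is a 3.4-fold higher number from compound 3 to compound 4 (0.53 log units; beyond the scatter) and it is expected to be upward. For compound 4 the estimate is 1400 mL.min-1.g-1 with an expected range from 550 mL.min-1.g-1 to 3500 mL.min-1.g-1 and the measurement is still to come.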

Compound 4, intrinsic clearance in microsomes: 1750 mL.min-1.g-1
Beside the measured number, compound 4's estimate is 1.3-fold (0.10 log units) below it, within the range that was stated.
By their numbers in this assay, from the lowest: compound 2; then compound 3; then compounds 4 and 1 (each within the scatter of the next).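

On the amide-type nitrogen in the ring, replacing pyridin-2-yl with the group of 10 heavy atoms, with its aromatic ring of carbon only and its 2 fluorine atoms, gives in this assay a 4.2-fold higher number from compound 3 to compound 4 (0.63 log units; beyond the scatter). With the phenyl-ended chain unchanged, this is the first step shown at this position, and it demonstrates that a change on this nitrogen alone can move the number beyond the scatter, whereas the earlier step lay on a saturated chain carbon. Nothing available explains the rise.

The compounds shown leave open whether the rise follows the ring of carbon only or the fluorine-bearing part of the entering group, a question that an unsubstituted phenyl on this nitrogen would address. From the compounds shown here alone, it is also open whether the same change would give a comparable step with the 1H-pyrazol-1-yl chain of compound 2 in place of the phenyl-ended chain.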